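From 2,5-difluorophenyl to 3,5-difluorophenyl

The source may hold more compounds than are shown below. What is called first, only, known or untested is meant among the compounds shown, and "the series" means these compounds.

In a functional assay with Homo sapiens as the target (on this read-out higher numbers stand for weaker inhibition and lower numbers for stronger inhibition), compound 2 `CC(C)[C@H](NC(=O)COc1cccc2ccccc12)C(=O)N[C@@H](CC(=O)O)C(=O)COc1cc(F)ccc1F` gives 19700 nM. Compound 1 `CC(C)[C@H](NC(=O)COc1cccc2ccccc12)C(=O)N[C@@H](CC(=O)O)C(=O)COc1ccc([N+](=O)[O-])cc1` gives 22800 nM, so the two stand within the scatter of each other. Compound 3 `CC(C)[C@H](NC(=O)COc1cccc2ccccc12)C(=O)N[C@@H](CC(=O)O)C(=O)COc1cc(F)cc(F)c1` keeps the core of compound 2 and carries 3,5-difluorophenyl in place of 2,5-difluorophenyl on an oxygen on a saturated carbon. Among the compounds with values here, only one measured step bears on this change: 2,5-difluorophenyl in place of 4-nitrophenyl on that same oxygen gave a 1.2-fold lower number from compound 1 to compound 2 (0.06 log units; within the scatter). Within the data shown here, no measured pair compares two fluorine patterns, so this evidence is indirect. Since even that larger exchange of groups left this assay essentially unmoved, no shift beyond the scatter is expected here, in either direction. The expected change is a 1.0-fold higher number from compound 2 to compound 3 (0.01 log units; within the scatter). For compound 3 the estimated value is 20000 nM, with an expected range of 10000 nM to 40000 nM.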

Compound 3, half-maximal inhibitory concentration: 15900 nM
Beside the measured number, compound 3's estimate is 1.3-fold (0.10 log units) above it, and the stated range covers the measured number.
By their numbers in this assay, from the lowest: compounds 3, 2 and 1 (each within the scatter of the next).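

This position now has its first direct comparison of two fluorine patterns: in this assay, 3,5-difluorophenyl in place of 2,5-difluorophenyl gives a 1.2-fold lower number from compound 2 to compound 3 (0.09 log units; within the scatter) on the same oxygen. The wider exchange, 3,5-difluorophenyl in place of 4-nitrophenyl, gives a 1.4-fold lower number from compound 1 to compound 3 (0.16 log units; within the scatter) and so also stays inside the scatter. Across these three groups, neither the fluorine pattern nor the exchange of nitro for fluorine separates the compounds in this read-out, and no separate measurement accounts for how close they stand.

The compounds shown leave open whether a phenyl carrying an amine or a carboxylic acid, or a longer chain in place of the ring, would move the number beyond the scatter. They also leave open whether this position would stay as insensitive with a change elsewhere in the shared core.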